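From 4-methoxybenzyl to 2,6-dichlorobenzyl in compound 3

This account rests on a few compounds, and the source may have more. Where it says the series, first, only, none or still open, it means among the compounds named here.

Among the measured compounds shown here, only two compounds have numbers so far. In a functional assay on LNCaP cells (Homo sapiens) for cytotoxicity, read by MTT assay (on this read-out lower numbers stand for stronger inhibition and higher numbers for weaker inhibition), compound 1 `COc1ccc2cc([C@H](C)c3nnc(SCc4c(Cl)cccc4Cl)n3-c3cccc(Cl)c3)ccc2c1` gives 73700 nM and compound 2 `COc1ccc(CSc2nnc([C@@H](C)c3ccc4cc(OC)ccc4c3)n2-c2ccc(F)cc2)cc1` gives 22800 nM as the lower of the two numbers, a gap beyond the usual scatter.

Compound 3 `COc1ccc2cc([C@H](C)c3nnc(SCc4c(Cl)cccc4Cl)n3-c3ccc(F)cc3)ccc2c1` has yet to be measured. It departs from compound 2 by a single change (2,6-dichlorophenyl in place of 4-methoxyphenyl on a saturated chain carbon bound to a sulfur), with 2,6-dichlorophenyl in place of 4-methoxyphenyl on a saturated chain carbon bound to a sulfur.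

For the measured compounds named here, no measured pair shows this change alone, so the evidence is thin. Going by the values given here, the one pointer is compound 1, which also carries the 2,6-dichlorophenyl group and reads 73700 nM on the higher side of the two numbers.

On that basis, a modest upward step is expected in this assay (the estimated 1.8-fold higher number from compound 2 to compound 3 (0.27 log units; within the scatter)), meaning somewhat weaker inhibition, with real uncertainty about its size. For compound 3 the expected half-maximal inhibitory concentration is 42000 nM (estimated range 15000 nM to 110000 nM).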

Compound 3, half-maximal inhibitory concentration: 12300 nM
Beside the measured number, compound 3's estimate is 3.4-fold (0.53 log units) above it; the measured number lies below the stated range.
By their numbers in this assay, from the lowest: compounds 3 and 2 (each within the scatter of the next); then compound 1.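

In this assay, among the compounds shown here, the first single change at this position, on a saturated chain carbon bound to a sulfur, stays within the scatter: 2,6-dichlorophenyl in place of 4-methoxyphenyl gives a 1.9-fold lower number from compound 2 to compound 3 (0.27 log units; within the scatter). The two groups differ in their atoms and in their hydrogen-bond acceptor count, yet this pair alone shows no separation between them in this assay. The step beyond the scatter lies elsewhere: with the 2,6-dichlorobenzyl group held in place, 4-fluorophenyl in place of 3-chlorophenyl on an aromatic nitrogen gives a 6.0-fold lower number from compound 1 to compound 3 (0.78 log units; beyond the scatter), so among these compounds the aromatic nitrogen is the one place where a single change clearly moves the number. Nothing among the data shown accounts for either step.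

The compounds shown leave open whether the step at the aromatic nitrogen would hold with the 4-methoxybenzyl group in place, since that comparison rests on a single pair. They also leave open how the sulfur position would read with something other than a substituted benzyl group, such as a longer alkyl chain or a chain ending in an amine or a carboxylic acid.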